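Mirror Image of the Most Potent Ring Compound

The compounds below may be only part of what the source reports. "The series", "measured", "known", "first", "only" and "open" are said of these compounds alone.

Compound 1, drawn as `C[C@]1(c2ccccc2)OCC[C@H](CCNCc2ccccc2)O1`, gives 11 nM in an assay on brain for displacement of a labelled ligand from Sigma non-opioid intracellular receptor 1 (Cavia porcellus) (on this read-out higher numbers stand for weaker inhibition and lower numbers for stronger inhibition), the lowest of the three numbers measured. Compound 2, `CC(C)(C)[C@]1(c2ccccc2)OCC[C@H](CCNCc2ccccc2)O1`, gives 253 nM, and compound 3, `c1ccc(CNCC[C@H]2CCO[C@@H](c3ccccc3)O2)cc1`, gives 50 nM. The two measured steps that start from compound 1 both change a substituent: a 23-fold higher number from compound 1 to compound 2 (1.36 log units; beyond the scatter) and a 4.5-fold higher number from compound 1 to compound 3 (0.66 log units; beyond the scatter). The third step, a 5.1-fold lower number from compound 2 to compound 3 (0.70 log units; beyond the scatter), connects those two substituents.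

Compound 4, `C[C@@]1(c2ccccc2)OCC[C@@H](CCNCc2ccccc2)O1`, is the mirror image of compound 1: the two compounds have the same atoms and bonds and differ only in configuration as drawn: 2 of 2 stereo elements differ (all stereocentres are inverted: mirror images); a stereocentre at a saturated ring carbon is drawn S in compound 1 and R in compound 4; a stereocentre at a saturated ring carbon is drawn S in compound 1 and R in compound 4. No atom leaves and none enters. Among the compounds with values here, none of the measured steps concerns a change in configuration, so they give no guide to the size or direction of this step. Mirror-image pairs commonly differ in this assay, and since compound 1 holds the lowest number of the set, its mirror image is expected, on balance, to give a higher number; the estimated step is a 3.2-fold higher number from compound 1 to compound 4 (0.50 log units; beyond the scatter). Compound 4 is therefore expected to give 35 nM, with a wide range from 8 nM to 200 nM.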

Compound 4, inhibition constant: 17 nM
For compound 4 the middle estimate is 2.1-fold (0.31 log units) above the measured one; the measured number falls inside the stated range.
By their numbers in this assay, from the lowest: compounds 1 and 4 (each within the scatter of the next); then compound 3; then compound 2.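

In this assay the new step is a 1.5-fold higher number from compound 1 to compound 4 (0.19 log units; within the scatter), so inverting both stereocentres leaves the number within the usual scatter, whereas every earlier step, each a change of substituent, lay beyond it. For the methyl compounds, then, the low number is not tied to one mirror-image form, and swapping the substituent on the saturated ring carbon moved the number more than inverting the whole molecule did. The comparison isolates configuration, since nothing else changes: the fact that compounds 1 and 4 differ only in the configuration as drawn

The compounds shown leave open what inverting only one of the two stereocentres would do, and whether the mirror images of compound 2 and compound 3 would also stay this close to their partners. They also leave open where an ethyl group in place of methyl would fall, in either mirror-image form.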